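A few compounds are considered here, and "the series" means these few. Any claim that something is new, unique, unknown or untested is made for them only; others in the source may bear on it.

Three compounds have been measured in a functional assay on HeLa cells (Homo sapiens) for inhibition, read by MTT assay, with a stated time of 48 h; on this read-out lower numbers stand for stronger inhibition of growth and higher numbers for weaker inhibition of growth:

Compound 1 `Cn1cc(C2CC(c3ccccc3)=NN2C(=O)c2cccnc2Cl)c2ccccc21`: > 10000 nM
Compound 2 `Cn1cc(C2CC(c3ccccc3)=NN2C(=O)c2cccnc2)c2cc(Br)ccc21`: 1730 nM
Compound 3 `Cn1cc(C2CC(c3ccc(Cl)cc3)=NN2C(=O)c2cccnc2)c2cc(Br)ccc21`: 5200 nM

The entry for compound 1 is a limit of the assay and not a number. Of the two true numbers, the higher belongs to compound 3, at 5200 nM, and the nearer comparison is compound 2, at 1730 nM.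

The next compound is compound 4 `COc1cc(C2=NN(C(=O)c3cccnc3)C(c3cn(C)c4ccc(Br)cc34)C2)cc(OC)c1OC`. The change is 3,4,5-trimethoxyphenyl in place of 4-chlorophenyl on a carbon with a double bond to nitrogen, which puts 3,4,5-trimethoxyphenyl in place of 4-chlorophenyl on a carbon with a double bond to nitrogen. Within the data shown here, one measured step bears on this place: a 3.0-fold higher number from compound 2 to compound 3 (0.48 log units; beyond the scatter), where chloro took the place of hydrogen on an aromatic carbon. That step is modest but beyond the scatter. Among the measured compounds shown here, no methoxy-bearing compound has been measured, so the guide is weak. In this assay, a step no larger than that one is expected, leaning toward a lower number. The expected change is a 1.7-fold lower number from compound 3 to compound 4 (0.24 log units; within the scatter). For compound 4 the estimate is 3000 nM, with an expected range from 800 nM to 10000 nM.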

Compound 4, concentration for 50% growth inhibition: > 10000 nM
Compound 4: a limit, no number; the forecaster's own chance of this, stated with the estimate: 15%; middle value at least 3.3-fold (0.52 log units) from the limit.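

The value of compound 4 in this assay is a limit of the assay and not a number: the limit of > 10000 nM in this assay, at which 2 of the 4 values shown sit. The earlier compounds held only one step at this position, and the wider replacement of phenyl on the carbon with a double bond to nitrogen now gives an at least 5.7-fold higher number from compound 2 to compound 4 (0.76 log units; beyond the scatter), so both substituted rings shown, in compound 3 and compound 4, read higher than the plain phenyl of compound 2. The comparison with the chloro compound is less firm, at an at least 1.9-fold higher number from compound 3 to compound 4 (0.28 log units; that floor lies within the scatter), which leaves the order of those two unsettled.

The compounds shown leave open how far compound 4 lies past its limit. They also leave open whether a single methoxy group or an amine on the phenyl ring would keep the number nearer that of compound 2.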